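The source may hold more compounds than are shown below. What is called first, only, known or untested is meant among the compounds shown, and "the series" means these compounds.

Compound 1, `CC(=O)OC[C@H]1O[C@@H](n2cc(CN3C(=O)/C(=C/C=C/c4ccccc4)c4ccccc43)nn2)[C@H](OC(C)=O)[C@@H](OC(C)=O)[C@@H]1OC(C)=O`, gives > 100000 nM in a functional assay on HeLa cells (Homo sapiens) for cytotoxicity, read by sulforhodamine B assay, with a stated time of 48 h; on this read-out lower numbers stand for stronger inhibition and higher numbers for weaker inhibition. Compound 2, `CC(=O)OC[C@H]1O[C@@H](n2cc(CN3C(=O)/C(=C/c4ccc5ccccc5c4)c4ccccc43)nn2)[C@H](OC(C)=O)[C@@H](OC(C)=O)[C@@H]1OC(C)=O`, gives > 100000 nM in this assay.

Both of these values are limits of the assay and not numbers. Among the measured compounds shown here, compound 2 therefore stands at the limit, and so does the one further value shown, since (the limit of > 100000 nM in this assay, at which 2 of the 2 values shown sit). For the measured compounds named here, the single measured step, from compound 1 to compound 2 with a step that the two limits leave unreadable from compound 1 to compound 2, cannot be read because both ends are limits.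

Compound 3, `CCC/C=C1/C(=O)N(Cc2cn([C@@H]3O[C@H](COC(C)=O)[C@@H](OC(C)=O)[C@H](OC(C)=O)[C@H]3OC(C)=O)nn2)c2ccccc21`, differs from compound 2 by propyl in place of naphthalen-2-yl on a double-bonded chain carbon bound to a double-bonded ring carbon. Going by the values given here, the only measured step that bears on this change, from compound 1 to compound 2, gives no readable size, so no direction can be drawn from it. With nothing to suggest a gain, compound 3 is expected to stay at the limit, the step being estimated as a number no higher from compound 2 to compound 3 (the limit leaves the size open). Compound 3 is accordingly estimated at 100000 nM, with a range from 30000 nM to 300000 nM.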

Compound 3, half-maximal inhibitory concentration: > 100000 nM
Compound 3: a limit, no number; the forecaster's own chance of this, stated with the estimate: 80%; the middle value sits exactly at the limit.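

In this assay, among the compounds shown here, compound 3 gives > 100000 nM, a limit and not a number, so neither the step to it from compound 1 nor the one from compound 2 can be read: the limit of > 100000 nM in this assay, at which 3 of the 3 values shown sit. The compounds shown leave open how naphthalen-2-yl, 2-phenylethenyl and propyl rank against one another at this place.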